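A few compounds are considered here, and "the series" means these few. Any claim that something is new, unique, unknown or untested is made for them only; others in the source may bear on it.

Measured in an ADME assay on a cell-free system (plasma, Homo sapiens) for metabolic stability, tested at 1 uM; a lower number here means that the compound disappears faster, a higher number that the compound lasts longer:
Compound 1 `C=CC(=O)NCC1CCN(S(=O)(=O)c2ccc(NC(=O)OCc3ccccc3)cc2)CC1`: > 6 h
Compound 2 `C=CC(=O)N1CCN(S(=O)(=O)c2ccc(NC(=O)OCc3ccccc3)cc2)CC1`: > 6 h
Compound 3 `C=CC(=O)N[C@H]1CCCN(S(=O)(=O)c2ccc(NC(=O)OCc3ccccc3)cc2)C1`: > 6 h

Compound 2 gives > 6 h, which is a limit of the assay and not a number. It therefore has no exact place in the set, and the overall picture is the limit of > 6 h in this assay, at which 3 of the 3 values shown sit. None of the three compounds can be ranked against the others.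

Compound 4 `C=CC(=O)N[C@@H]1CCN(S(=O)(=O)c2ccc(NC(=O)OCc3ccccc3)cc2)C1` has not yet been measured. It differs from compound 2 on a sulfonyl sulfur, with 3-((vinylcarbonyl)amino)pyrrolidin-1-yl in place of 4-(vinylcarbonyl)piperazin-1-yl on a sulfonyl sulfur. For the measured compounds named here, no pair of measured compounds shows this change on its own, so its effect in this assay can only be expected.

Compound 3 also carries a (vinylcarbonyl)amino group and gives > 6 h, again a limit. On that basis, no step beyond the scatter is expected in either direction. The expected step is a step that the limit leaves unreadable from compound 2 to compound 4. For compound 4 the estimate is 8 h, with an expected range from 5 h to 20 h.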

Compound 4, half-life: > 6 h
Compound 4 ended at the assay's limit; the forecaster's own chance of this, stated with the estimate: 85%; the middle value is on the limit's open side.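

In this assay compound 4 gives > 6 h, which is a limit of the assay and not a number. Compound 2 also sits at a limit, so no step can be read from compound 2 to compound 4. The compounds shown leave open how long each one actually lasts in this assay and how they rank against one another.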